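Aryl-to-pyridyl swap on the thiazole acetic acid series

This account rests on a few compounds, and the source may have more. Where it says the series, first, only, none or still open, it means among the compounds named here.

Measured so far:
- compound 1, `CCC(c1ccccc1)c1nc(-c2ccc(Cl)cc2)c(CC(=O)O)s1`: > 100000 nM
- compound 2, `O=C(O)Cc1sc(NC(=O)c2ccccc2)nc1-c1ccc(Cl)cc1`: 870 nM
- compound 3, `O=C(O)Cc1sc(C(c2ccc(F)cc2)c2ccc(F)cc2)nc1-c1cc(F)cc(F)c1`: 340 nM

In an in vitro functional assay on HEK285-7 cells for antagonist activity at prostaglandin D2 receptor 2 (Homo sapiens), read by BRET and beta-arrestin recruitment (on this read-out lower numbers stand for stronger inhibition and higher numbers for weaker inhibition), compound 3 gives 340 nM, the lowest of the two numbers in hand. Compound 2 gives 870 nM in this assay, a higher number than compound 3, and the gap between the two lies beyond the scatter. For compound 1 this assay reports only a limit, > 100000 nM (the limit of > 100000 nM in this assay, at which 1 of the 3 values shown sits), not a number, so it cannot be set against the other two.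

Among the measured compounds shown here, no step between two measured compounds differs in one place, so no measured change guides the next one. Compound 4, `O=C(O)Cc1sc(C(c2ccc(F)cc2)c2ccc(F)cc2)nc1-c1cc(F)nc(F)c1`, carries 2,6-difluoropyridin-4-yl in place of 3,5-difluorophenyl on an aromatic carbon.

Given that compound 3 gives 340 nM and the change leaves the rest of the structure untouched, a step of no more than the scatter is expected, with no clear direction. For compound 4 the estimate in this assay is 500 nM, with a range from 150 nM to 1700 nM, which means an expected step of a 1.5-fold higher number from compound 3 to compound 4 (0.17 log units; within the scatter).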

Compound 4, half-maximal inhibitory concentration: 110 nM
For compound 4 the middle estimate is 4.5-fold (0.66 log units) above the measured one, and the stated range ends above it.
By their numbers in this assay, from the lowest: compound 4; then compound 3; then compound 2. At a limit, above all of these: compound 1.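

In this assay, among the compounds shown here, 2,6-difluoropyridin-4-yl in place of 3,5-difluorophenyl gives a 3.1-fold lower number from compound 3 to compound 4 (0.49 log units; beyond the scatter) and is the first step that differs in one place. The position on the aromatic carbon next to the ring nitrogen, next to the ring atom that bears a carboxymethyl group, thus responds to a change inside the aryl ring: the heavy-atom count stays the same, while one ring carbon gives way to a ring nitrogen and one hydrogen-bond acceptor enters. No measurement shown bears on the reason for this step.

Still open, as far as these compounds go, is whether the ring nitrogen alone accounts for the step or whether the fluorine atoms are needed with it, which an unsubstituted pyridin-4-yl group would separate. Also open, from the compounds shown here alone, is whether the step carries over to the shared core with a different large group, such as the benzoylamino group of compound 2.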